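Trimming the Amide Ring of a Nitrile Inhibitor

This account rests on a few compounds, and the source may have more. Where it says the series, first, only, none or still open, it means among the compounds named here.

Of the compounds shown here, two have so far been measured in a functional assay on A20 cells (Mus musculus) for inhibition, with stated times of 1 h, 16 h and 24 h; a higher number here means a weaker inhibitor, a lower number a stronger inhibitor. Compound 1 `N#CCNC(=O)[C@@H]1CC(F)(F)C[C@H]1C(=O)N1CCOCC1` gives 925 nM. For the measured compounds named here, compound 2 `N#CC1(NC(=O)[C@@H]2C[C@@H](S(=O)(=O)c3ccccc3)C[C@H]2C(=O)N2CC3CCC(C2)O3)CC1` gives 16 nM, the lowest of the two numbers; compound 1, its only neighbour, sits far above it, well beyond the usual scatter. Compound 3 `N#CC1(NC(=O)[C@@H]2C[C@@H](S(=O)(=O)c3ccccc3)C[C@H]2C(=O)N2CCC2)CC1` has not yet been measured. It departs from compound 2 in one place: a group of 4 heavy atoms (3 carbon, 1 nitrogen; one four-membered non-aromatic ring with 1 hetero atom) in place of a group of 8 heavy atoms (6 carbon, 1 nitrogen, 1 oxygen; one five-membered non-aromatic ring with 1 hetero atom, one six-membered non-aromatic ring with 2 hetero atoms), on a carbonyl carbon. Going by the values given here, no measured pair differs in just one place, so no measured step exists to guide the guess, and compound 1 and compound 2 differ from each other in several places at once. In the absence of such a step, a small weakening is expected from compound 2 to compound 3, a 3.1-fold higher number from compound 2 to compound 3 (0.49 log units; beyond the scatter), though the data cannot rule out a change within the scatter. Compound 3 is therefore estimated at 50 nM in this assay, with a likely range from 12 nM to 200 nM.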

Compound 3, half-maximal inhibitory concentration: 44 nM
Beside the measured number, compound 3's estimate is 1.1-fold (0.06 log units) above it; the measured number falls inside the stated range.
By their numbers in this assay, from the lowest: compound 2; then compound 3; then compound 1.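

For the compounds shown here, this is the first comparison in which only one place changes, so the effect of the group on the carbonyl carbon can be read on its own. In this assay, putting azetidin-1-yl in place of the larger group of 8 heavy atoms gives a 2.8-fold higher number from compound 2 to compound 3 (0.44 log units; beyond the scatter). The position therefore responds to the group it carries, but the step is modest, so this group can shrink to 4 heavy atoms and lose its oxygen at limited cost; nothing available explains why the number rises.

From the compounds shown here alone, whether the rise follows the size of the group or the loss of its oxygen stays open, as both change together in this one step. A piperidin-1-yl group, a larger ring that also has no oxygen, would help separate the two.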